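The source may hold more compounds than are shown below. What is called first, only, known or untested is meant among the compounds shown, and "the series" means these compounds.

Working notes on the series. Compound 1 `COc1cc(/C=C/C(=O)c2ccncc2)cc(OC)c1OC` gives 58 nM in an assay on HEK293 cells for inhibition of cytochrome P450 1A1 (Homo sapiens), read by fluorescence, with stated times of 30 min and 60 min; on this read-out higher numbers stand for weaker inhibition and lower numbers for stronger inhibition. Among the three measured compounds it sits at the low end, together with compound 2 `CCOc1cc(/C=C/C(=O)c2ccncc2)cc(OC)c1OC`, which gives 63 nM; the step of a 1.1-fold higher number from compound 1 to compound 2 (0.04 log units; within the scatter) does not separate the two. Going by the values given here, compound 3 `COc1ccccc1/C=C/C(=O)c1ccncc1` gives 610 nM, a higher number than compound 1 by a gap that lies beyond the scatter; no single-point step links these two, as they differ in several places.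

Compound 4 `COc1cc(/C=C/C(=O)c2ccncc2)cc(OC)c1` is the next member. Relative to compound 1 the change is hydrogen in place of methoxy on an aromatic carbon. Among the compounds with values here, the only measured single-point step, from compound 1 to compound 2, alters the alkoxy chain and leaves all three oxygen substituents in place, so it bears only loosely on a change that removes one of them. Compound 3, carrying a single methoxy, shows that fewer such groups can go with a clearly higher number, but its substitution differs from compound 4 in more than one respect.

On this basis a moderately higher number is expected for compound 4 in this assay, with an estimated step of a 2.6-fold higher number from compound 1 to compound 4 (0.41 log units; beyond the scatter), and an estimated value of 150 nM, in the range 50 nM to 500 nM.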

Compound 4, half-maximal inhibitory concentration: 220 nM
For compound 4 the middle estimate is 1.5-fold (0.17 log units) below the measured one; the measured number falls inside the stated range.
By their numbers in this assay, from the lowest: compounds 1 and 2 (each within the scatter of the next); then compound 4; then compound 3.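

In this assay, replacing the methoxy that is ortho to two methoxy groups and para to a large group with hydrogen gives a 3.8-fold higher number from compound 1 to compound 4 (0.58 log units; beyond the scatter), a modest step beyond the scatter. Going by these compounds alone, this is the first single-point change to clearly move the number, whereas the change on the alkoxy chain, a 1.1-fold higher number from compound 1 to compound 2 (0.04 log units; within the scatter), stays within the scatter; this methoxy therefore matters more to the read-out than the added methyl does, at least for these two changes. Even so, compound 4 still gives 220 nM with hydrogen at this position, so inhibition does not depend entirely on this methoxy, and no measured evidence bears on what lies behind the step.

As far as these compounds go, it remains open how other groups at this position, such as hydroxyl, fluorine, an amine or a longer chain like propoxy, would compare with methoxy and hydrogen. Also open, from the compounds shown here alone, is whether removing either of the other two methoxy groups on its own would give a step of similar size.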